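From Methyl to Chloro: What to Expect for Compound 4

The compounds below may be only part of what the source reports. "The series", "measured", "known", "first", "only" and "open" are said of these compounds alone.

Of the compounds shown here, three have been measured in an assay on isolated protein with adenosine receptor A1 (Homo sapiens) as the target, read by ERK phosphorylation; a lower number here means a less potent compound, a higher number a more potent compound, by a factor of ten per unit of this negative logarithm. Compound 1 `Nc1sc2c(c1C(=O)c1ccccc1)CCCCCC2` gives 5.08, compound 2 `Nc1sc(-c2ccccc2)cc1C(=O)c1ccccc1` gives 6.36, and compound 3 `Cc1ccc(C(=O)c2c(N)sc3c2CCCC3)cc1` gives 5.1. Compound 3 thus stands second highest of the three: its number lies within the usual scatter of compound 1, so the two cannot be told apart, while compound 2 sits above it by a gap beyond the scatter. Compound 4 `Nc1sc2c(c1C(=O)c1ccc(Cl)cc1)CCCC2` has not yet been measured. It differs from compound 3 in one place: chloro in place of methyl on an aromatic carbon. For the measured compounds named here, no measured pair shows this kind of change, so there is no measured step to lean on. The expectation is that compound 4 stays close, with a step of a number 0.20 log units higher from compound 3 to compound 4 (within the scatter) that does not clearly exceed the scatter. Compound 4 is therefore estimated at 5.3, with a likely range from 4.6 to 6.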

Compound 4, negative logarithm of the antagonist equilibrium constant: 5.49
Compound 4: middle estimate off by 0.19 log units, on the low side; measured number inside the range.
By their numbers in this assay, from the lowest: compounds 1 and 3 (each within the scatter of the next); then compound 4; then compound 2.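

For the compounds shown here, on the aromatic carbon para to a large group, chloro in place of methyl gives the only single-place step so far in this assay, with a number 0.39 log units higher from compound 3 to compound 4 (beyond the scatter) as a modest move. Going by these compounds alone, it shows that exchanging one heavy atom at this position can shift the number beyond the scatter, which the earlier compounds could not show. No available measurement explains this shift. As far as these compounds go, whether a methoxy group or an amine at this position would move the number further remains open, as does whether chloro in place of methyl gives a similar step on the core of compound 2.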